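The source may hold more compounds than are shown below. What is called first, only, known or untested is meant among the compounds shown, and "the series" means these compounds.

Measured so far in a functional assay on MOLT-4 cells (Homo sapiens) for inhibition, read by MTT assay, with a stated time of 72 h; on this read-out lower numbers stand for stronger inhibition and higher numbers for weaker inhibition:
- compound 1 `COc1cc(NC(C)CCCNC(=O)NNC(=O)Nc2ccc(Cl)cc2)c2ncccc2c1` gives 186000 nM
- compound 2 `COc1cc(NC(C)CCCNC(=O)NNC(=O)Nc2cccc(C(F)(F)F)c2)c2ncccc2c1` gives 36000 nM

Compound 2 holds the lower of these two numbers. Compound 3 `COc1cc(NC(C)CCCNC(=O)NNC(=O)Nc2cc(C(F)(F)F)cc(C(F)(F)F)c2)c2ncccc2c1` differs from compound 2 by trifluoromethyl in place of hydrogen on an aromatic carbon, with trifluoromethyl in place of hydrogen on an aromatic carbon. For the measured compounds named here, one measured step bears on this, a 5.2-fold lower number from compound 1 to compound 2 (0.71 log units; beyond the scatter), a modest change on the same aromatic ring, though not the same substitution. A further modest lowering is therefore expected, and the estimated step is a 2.6-fold lower number from compound 2 to compound 3 (0.41 log units; beyond the scatter) in this assay overall. For compound 3 the estimated value is 14000 nM, with an expected range from 3500 nM to 50000 nM on this read-out.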

Compound 3, half-maximal inhibitory concentration: 22000 nM
Compound 3: middle estimate off by 1.6-fold (0.20 log units), on the low side; the range from low to high includes it.
By their numbers in this assay, from the lowest: compounds 3 and 2 (each within the scatter of the next); then compound 1.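

In this assay, adding trifluoromethyl on the aromatic ring, meta to a trifluoromethyl group, gives a 1.6-fold lower number from compound 2 to compound 3 (0.21 log units; within the scatter). This second trifluoromethyl therefore does not separate compound 3 from compound 2, whereas the earlier ring change gave a 5.2-fold lower number from compound 1 to compound 2 (0.71 log units; beyond the scatter). No available evidence accounts for this result.

Going by these compounds, it remains open whether an amine or a carboxylic acid at this position would shift the number beyond the scatter. The effect of a longer chain on the shared core is also unresolved.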